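Inverting a ring stereocentre on the cyclopentyl aminomethyl indole

The source may hold more compounds than are shown below. What is called first, only, known or untested is meant among the compounds shown, and "the series" means these compounds.

The series gathers four indole nitriles that share a saturated ring bearing an aminomethyl arm. Compound 1 `CN(C)C[C@@H]1C[C@H]1c1ccc2[nH]cc(C#N)c2c1` and compound 2 `CN(C)C[C@@H]1CCC[C@H]1c1ccc2[nH]cc(C#N)c2c1` carry a dimethylamino arm. In an assay on HEK293 cells for displacement of a labelled ligand from sodium-dependent dopamine transporter (Homo sapiens) (on this read-out higher numbers stand for weaker inhibition and lower numbers for stronger inhibition), compound 1 gives "not determined" (no result reported), and in this assay compound 2 gives "not determined" (no result reported), so for neither of them was a result reported. Among the compounds with values here, compound 3 `CNC[C@@H]1CCC[C@H]1c1ccc2[nH]cc(C#N)c2c1` carries a methylamino arm on the five-membered ring, and in this assay compound 3 gives 750 nM, the only number the set holds, so it stands alone with nothing to be ranked against.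

Compound 4 `CNC[C@H]1CCC[C@H]1c1ccc2[nH]cc(C#N)c2c1` is its stereoisomer. Compared with compound 3, the change is the two compounds have the same atoms and bonds and differ only in configuration as drawn: 1 of 2 stereo elements differ; a stereocentre at a saturated ring carbon is drawn R in compound 3 and S in compound 4. Within the data shown here, no pair of measured compounds in this set differs in one place, so no measured step gives a scale for such an inversion. Inverting a ring stereocentre is nonetheless the kind of change that can move binding either way, and a loss of potency is expected more often than a gain. Compound 4 is therefore estimated at 1800 nM, within a range of 400 nM to 8000 nM. This estimate means a step of a 2.4-fold higher number from compound 3 to compound 4 (0.38 log units; beyond the scatter) towards weaker inhibition, expected to exceed the scatter but with wide uncertainty.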

Compound 4, half-maximal inhibitory concentration: 660 nM
Beside the measured number, compound 4's estimate is 2.7-fold (0.44 log units) above it, within the range that was stated.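

In this assay, within the data shown here, the inversion gives a 1.1-fold lower number from compound 3 to compound 4 (0.06 log units; within the scatter) and so yields the first measured step in this set. At this saturated ring carbon, drawn R in compound 3 and S in compound 4, the two readings cannot be told apart, which shows that with the methylamino arm on the five-membered ring this inversion carries no change in dopamine transporter binding beyond the usual scatter. The comparison isolates configuration at that one carbon: the fact that compounds 3 and 4 differ only in the configuration as drawn.

As far as these compounds go, what stays open is whether the second stereocentre, the one carrying the aromatic core, would tolerate inversion in the same way. From the compounds shown here alone, it is equally open whether this one would do so with a primary amine or a longer chain in place of the methylamino arm.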